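The source may report more compounds than this note shows. Statements on the series, on what has been measured and on what is new or still open speak of the compounds shown alone.

In a functional assay on the whole organism (strain Fischer 344) for inhibition, with Rattus norvegicus as the target, read by paw edema, at a dose of 0.01 mmol/kg by the intraperitoneal route (a higher number here means more inhibition at the dose given (going by the name of the read-out), a lower number less inhibition), compound 3 `Cn1c(=O)c(C(=O)NCCN)c(O)c2ccccc21` gives 67%. Compound 1 `COC(=O)c1c(O)c2ccccc2n(C)c1=O` gives 58.8%, and these two numbers sit within the scatter of each other, so no order between them can be claimed. Compound 2 `COC(=O)c1c(O)c2ccccc2n(-c2ccccc2)c1=O` gives 37.1%, which lies beyond the scatter below compound 3. Compound 4 `NCCNC(=O)c1c(O)c2ccccc2n(-c2ccccc2)c1=O` differs from compound 3 by phenyl in place of methyl on an aromatic nitrogen. For the measured compounds named here, one measured step bears directly on this change: the same swap, a number 21.7 percentage points lower from compound 1 to compound 2 (beyond the scatter). The step from compound 1 to compound 3 was a number 8.2 percentage points higher from compound 1 to compound 3 (within the scatter) and is not the change in question. A drop of similar size is therefore expected, a number 22 percentage points lower from compound 3 to compound 4 (beyond the scatter), and compound 4 is estimated at 45%, within 30% to 60%.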

Compound 4, a percentage reported as inhibition, in the whole organism at one dose (the size of the read-out at that dose, not a potency): 68.1%
Compound 4: middle estimate off by 23.1 percentage points, on the low side; measured number outside the range, above it.
By their numbers in this assay, from the lowest: compound 2; then compounds 1, 3 and 4 (each within the scatter of the next).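

On the methoxy compounds, phenyl in place of methyl lowered the number, but with the (2-aminoethyl)carbamoyl group present the same swap gives a number 1.1 percentage points higher from compound 3 to compound 4 (within the scatter) in this assay. The effect of this change on the aromatic nitrogen therefore depends on the rest of the molecule: the same change on two cores in this assay, a number 21.7 percentage points lower (beyond the scatter) from compound 1 to compound 2 and a number 1.1 percentage points higher (within the scatter) from compound 3 to compound 4, 22.8 percentage points apart, beyond the scatter of two such steps. Seen from the other side, (2-aminoethyl)amino in place of methoxy gives a number 31 percentage points higher from compound 2 to compound 4 (beyond the scatter), a much larger step with phenyl on the nitrogen than with methyl: the same change on two cores in this assay, a number 8.2 percentage points higher (within the scatter) from compound 1 to compound 3 and a number 31 percentage points higher (beyond the scatter) from compound 2 to compound 4, 22.8 percentage points apart, beyond the scatter of two such steps.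

From the compounds shown here alone, it remains open whether a benzyl group on that nitrogen would follow phenyl or methyl. Also open, going by these compounds, is whether the chain needs its terminal amine, or whether a carboxylic acid there would serve equally.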